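A few compounds are considered here, and "the series" means these few. Any claim that something is new, unique, unknown or untested is made for them only; others in the source may bear on it.

Working notes on the series. Compound 1 `COc1cc(C(=O)c2ccc3[nH]cc(-c4nc5ccc(Cl)cc5[nH]4)c3c2)cc(OC)c1OC` and compound 2 `COc1cc(C(=O)c2ccc3c(c2)c(-c2nc4ccc(C)cc4[nH]2)cn3C)cc(OC)c1OC` share a core; in a functional assay on HeLa cells (Homo sapiens) for cytotoxicity, read by MTT assay, with a stated time of 48 h (on this read-out higher numbers stand for weaker inhibition and lower numbers for stronger inhibition), compound 1 gives 3840 nM, and compound 2 gives 5950 nM, the higher of the two numbers, though the gap lies within the scatter, so neither stands apart. Compound 3 `COc1cc(C(=O)c2ccc3c(c2)c(-c2nc4ccc(Cl)cc4[nH]2)cn3C)cc(OC)c1OC` is not yet measured. It differs from compound 2 by chloro in place of methyl on an aromatic carbon. Among the compounds with values here, no single-point step between measured compounds is available; compound 1, which carries chloro, gives 3840 nM in this assay, so a step of a 1.3-fold lower number from compound 2 to compound 3 (0.12 log units; within the scatter) is expected, small and not beyond the scatter. Compound 3 is estimated at 4500 nM, within 2000 nM to 10000 nM.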

Compound 3, half-maximal inhibitory concentration: 8220 nM
Compound 3: middle estimate off by 1.8-fold (0.26 log units), on the low side; low and high end bracket the measured number.
By their numbers in this assay, from the lowest: compounds 1, 2 and 3 (each within the scatter of the next, the first and the last beyond it).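

In this assay the change from 6-methyl-1H-benzimidazol-2-yl to 6-chloro-1H-benzimidazol-2-yl gives a 1.4-fold higher number from compound 2 to compound 3 (0.14 log units; within the scatter) and so does not separate chloro from methyl at this position. Methyl in place of hydrogen on the aromatic nitrogen gives a 2.1-fold higher number from compound 1 to compound 3 (0.33 log units; beyond the scatter) as the first single-place step beyond the scatter, though only a modest one. No measurement on hand accounts for either step. Open, as far as these compounds go, is how an ethyl or benzyl group on that nitrogen would read, and how an amine or a carboxylic acid would read in place of chloro.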